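The source may report more compounds than this note shows. Statements on the series, on what has been measured and on what is new or still open speak of the compounds shown alone.

Measured compounds:
- compound 1, `COCCc1cn(-c2ccccc2)[nH]c1=O`: > 1000 nM, a limit of the assay rather than a number
- compound 2, `COCCC1CN(c2ccc(Cl)c(Cl)c2)NC1=O`: 190 nM
- compound 3, `COCCC1CN(c2ccc(Cl)cc2)NC1=O`: 250 nM

All three were tested in an assay on isolated protein for inhibition of Polyunsaturated fatty acid 5-lipoxygenase (Rattus norvegicus); a lower number here means a stronger inhibitor, a higher number a weaker inhibitor. Compound 3 has the highest of the two numbers shown, with compound 2 nearest at a lower number that lies within the scatter. For compound 1 the result is the limit of > 1000 nM in this assay, at which 1 of the 3 values shown sits.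

Compound 4 `COCCC1CN(c2ccc(OC)cc2)NC1=O` differs from compound 3 by methoxy in place of chloro on an aromatic carbon. Going by the values given here, the only measured step touching that position, a 1.3-fold higher number from compound 2 to compound 3 (0.12 log units; within the scatter), removed a chloro and stayed within the scatter, so exchanging the remaining chloro for methoxy is expected to move the number only slightly. Compound 4 is estimated at 350 nM, with a range from 120 nM to 1000 nM. This estimate means an expected step of a 1.4-fold higher number from compound 3 to compound 4 (0.15 log units; within the scatter).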

Compound 4, half-maximal inhibitory concentration: 1460 nM
Compound 4: middle estimate off by 4.2-fold (0.62 log units), on the low side, outside the stated range (above it).
By their numbers in this assay, from the lowest: compounds 2 and 3 (each within the scatter of the next); then compound 4.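

In this assay methoxy in place of chloro on this aromatic carbon, para to a large group, gives a 5.8-fold higher number from compound 3 to compound 4 (0.77 log units; beyond the scatter) and so weakens inhibition measurably. The earlier chloro step, a 1.3-fold higher number from compound 2 to compound 3 (0.12 log units; within the scatter) and thus within the scatter, gave no sign that a change on this ring could matter this much. Nothing measured here accounts for the weakening. Still open, on these data alone, is whether losing the chloro or gaining the methoxy drives this step. Hydrogen, methyl or an amine on the same carbon would help separate the two.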